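The source may hold more compounds than are shown below. What is called first, only, known or untested is meant among the compounds shown, and "the series" means these compounds.

In a functional assay (plasma) for inhibition, with Homo sapiens as the target (a higher number here means a weaker inhibitor, a lower number a stronger inhibitor), compound 2 `O=C(O)CCC/C=C\CC1C2CCC(O2)C1COCC1CCCCC1` gives 165000 nM, the higher of the two single numbers in this small set. Compound 3 `CCC/C=C/COCC1C2CCC(O2)C1C/C=C\CCCC(=O)O` stands nearest at 300 nM. The measured change is a 550-fold lower number from compound 2 to compound 3 (2.74 log units; beyond the scatter), with pent-1-en-1-yl in place of cyclohexyl. Compound 1 `CCCCCCOC[C@@H]1C2CCC(O2)[C@H]1C/C=C\CCCC(=O)O` has no single number: its entries are 25000 nM; 18000 nM; 500 nM (3 entries), so it offers only a loose guide.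

The step followed here leads to compound 4 `CCCCC(C)COCC1C2CCC(O2)C1C/C=C\CCCC(=O)O`: 1-methylpentyl in place of cyclohexyl on a saturated chain carbon bound to an oxygen on a saturated carbon. Here 1-methylpentyl stands in place of cyclohexyl on a saturated chain carbon bound to an oxygen on a saturated carbon, so a group with no ring again replaces the cyclohexyl. Going by the values given here, the one measured step that bears on this is the large one to compound 3, a 550-fold lower number from compound 2 to compound 3 (2.74 log units; beyond the scatter), and a large fall in this assay is therefore expected, in the same direction and perhaps somewhat smaller. The expected change is a 55-fold lower number from compound 2 to compound 4 (1.74 log units; beyond the scatter). Compound 4 is estimated at 3000 nM, with an expected range from 300 nM to 30000 nM.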

Compound 4, half-maximal inhibitory concentration: 7400 nM
Estimate against measurement, compound 4: 2.5-fold (0.39 log units) below, within the range that was stated.
By their numbers in this assay, from the lowest: compound 3; then compound 4; then compound 2.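

In this assay, removing the ring at this place again brings a large fall, a 22-fold lower number from compound 2 to compound 4 (1.35 log units; beyond the scatter), so both groups with no ring, pent-1-en-1-yl and 1-methylpentyl, give lower numbers than cyclohexyl. The loss of the ring does not settle the value on its own, however: two groups without a ring still stand well apart, a 25-fold higher number from compound 3 to compound 4 (1.39 log units; beyond the scatter). The place on a saturated chain carbon bound to an oxygen therefore distinguishes between acyclic groups as well as between cyclic and acyclic ones.

Going by these compounds, how a phenyl ring or a longer chain would read at this place remains open. The separate contributions of the branch in 1-methylpentyl and the double bond in pent-1-en-1-yl also remain unresolved, and the unbranched saturated chain of compound 1 gives no single number to settle this: the several entries of compound 1 in this assay, 25000 nM; 18000 nM; 500 nM (3 entries)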